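The compounds below may be only part of what the source reports. "The series", "measured", "known", "first", "only" and "open" are said of these compounds alone.

Among the compounds with values here, the three compounds measured so far share one core and differ only in the group attached to it. Compound 1 `COc1cc(C(=O)c2sc(-c3ccc([N+](=O)[O-])cc3)cc2N)cc(OC)c1OC` carries a 4-nitrophenyl group; in a functional assay on L1210 cells (Mus musculus) for antiproliferative activity (a higher number here means a weaker inhibitor, a lower number a stronger inhibitor), compound 1 gives 100 nM. Compound 2 `COc1cc(C(=O)c2sc(-c3ccc(Cl)c(Cl)c3)cc2N)cc(OC)c1OC` gives 260 nM in this assay, and compound 3 `COc1cccc(-c2cc(N)c(C(=O)c3cc(OC)c(OC)c(OC)c3)s2)c1` gives 22 nM. Compound 1 thus stands second highest of the three numbers: a 2.6-fold higher number from compound 1 to compound 2 (0.41 log units; beyond the scatter) and a 4.5-fold lower number from compound 1 to compound 3 (0.66 log units; beyond the scatter). Between the other two, a 12-fold lower number from compound 2 to compound 3 (1.07 log units; beyond the scatter).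

Compound 4 `CCOc1ccc(-c2cc(N)c(C(=O)c3cc(OC)c(OC)c(OC)c3)s2)cc1` has not yet been measured. It differs from compound 1 in one place: ethoxy in place of nitro on an aromatic carbon. Within the data shown here, no measured step makes exactly this change. The two steps that start from compound 1 are the nearest guides: a 4.5-fold lower number from compound 1 to compound 3 (0.66 log units; beyond the scatter) put a methoxy-bearing ring in place of the 4-nitrophenyl and lowered the number, while a 2.6-fold higher number from compound 1 to compound 2 (0.41 log units; beyond the scatter) put a chlorine-bearing ring in and raised it. Compound 3 shows that a ring carrying an oxygen-linked alkyl group can give a lower number than compound 1, so a modest step downward is expected for compound 4, a 2.0-fold lower number from compound 1 to compound 4 (0.30 log units; within the scatter), although the ethoxy of compound 4 does not sit where the methoxy of compound 3 does, which leaves the expectation uncertain. Compound 4 is estimated to give 50 nM in this assay, with a likely range from 15 nM to 200 nM.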

Compound 4, half-maximal inhibitory concentration: 590 nM
Compound 4: the middle estimate sits 12-fold (1.07 log units) below what was measured; measured number outside the range, above it.
By their numbers in this assay, from the lowest: compound 3; then compound 1; then compound 2; then compound 4.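

In this assay, an oxygen-linked alkyl group on the outer ring does not by itself give a low number (a 27-fold higher number from compound 3 to compound 4 (1.43 log units; beyond the scatter)), so the 3-methoxyphenyl and 4-ethoxyphenyl rings, which both carry such a group, sit at opposite ends of the series. At this carbon, para to a large group, ethoxy gives a higher number than nitro (a 5.9-fold higher number from compound 1 to compound 4 (0.77 log units; beyond the scatter)), and the 4-ethoxyphenyl ring also gives a higher number than the 3,4-dichlorophenyl ring (a 2.3-fold higher number from compound 2 to compound 4 (0.36 log units; beyond the scatter)), which makes compound 4, with steps beyond the scatter to all three others, the weakest of the four. No measurement at hand accounts for why the ethoxy group raises the number this far.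

Compound 3 and compound 4 differ both in the length of the oxygen-linked chain and in where it sits on the ring, so these compounds cannot separate the two changes, and a 4-methoxyphenyl or a 3-ethoxyphenyl ring would be needed to do so. As far as these compounds go, how a nitrogen-linked group such as a 4-dimethylaminophenyl ring, or a longer chain such as 4-butoxyphenyl, would behave at this carbon also remains open.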